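This account rests on a few compounds, and the source may have more. Where it says the series, first, only, none or still open, it means among the compounds named here.

Measured compounds:
compound 1 `COc1cccc(CNCCCCCCNCCCCCCNCCCCCCNCc2ccccc2OC)c1` — 6.21
compound 2 `COc1cc2nc(N3CCN(C(=O)c4ccccc4C(F)(F)F)CC3)nc(N)c2cc1OC` — 8.31
compound 3 `COc1cc2nc(N3CCN(C(=O)c4cccc(C(F)(F)F)c4)CC3)nc(N)c2cc1OC` — 8.38

In a functional assay on thoracic aorta for antagonist activity at Alpha-1D adrenergic receptor (Rattus norvegicus) (on this read-out higher numbers stand for higher potency (the scale is a negative logarithm) and lower numbers for lower potency), compound 3 and compound 2 sit within the scatter of each other, while compound 1 lies far lower, beyond the scatter. Compound 4 `COc1cc2nc(N3CCN(C(=O)c4ccc(C(F)(F)F)cc4)CC3)nc(N)c2cc1OC` is the next member; its difference from compound 3 is 4-(trifluoromethyl)phenyl in place of 3-(trifluoromethyl)phenyl on a carbonyl carbon. Among the compounds with values here, one measured step bears on this: a number 0.07 log units higher from compound 2 to compound 3 (within the scatter), a move of the trifluoromethyl around the same ring on the same carbonyl carbon, which produced nothing beyond the scatter. A second move of the same group on the same carbonyl carbon is therefore expected to give a number 0.08 log units lower from compound 3 to compound 4 (within the scatter), no step beyond the scatter. Compound 4 is estimated at 8.3, with a range from 7.8 to 8.8.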

Compound 4, negative logarithm of the antagonist equilibrium constant: 8.31
Beside the measured number, compound 4's estimate is 0.01 log units below it; the measured number falls inside the stated range.
By their numbers in this assay, from the lowest: compound 1; then compounds 2, 4 and 3 (each within the scatter of the next).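

Moving to 4-(trifluoromethyl)phenyl in this assay gives a number 0.07 log units lower from compound 3 to compound 4 (within the scatter) and no change at the digits printed from compound 2 to compound 4 (within the scatter) and so puts all three trifluoromethyl placements on this carbonyl carbon within the scatter of each other. Across compounds 2, 3 and 4, this read-out therefore does not separate the placements of the trifluoromethyl on the phenyl ring. Nothing measured here accounts for that flat result.

Still open, as far as these compounds go, is whether a carboxylic acid or an amine in place of the trifluoromethyl would stay within the scatter. Also open, from the compounds shown here alone, is whether an alkyl chain in place of the whole phenyl ring would do so.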